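Replacing 3-methoxybenzyl with 4-methylphenyl on the shared core

The source may hold more compounds than are shown below. What is called first, only, known or untested is meant among the compounds shown, and "the series" means these compounds.

In an ADME assay on L02 cells (Homo sapiens) for inhibition, read by CCK-8 assay, with a stated time of 48 h (on this read-out higher numbers stand for weaker inhibition of growth and lower numbers for stronger inhibition of growth), compound 1 `CN1CCN(c2ccc(Nc3ncc(Cl)c(Nc4ccccc4)n3)nc2)CC1` gives 7990 nM and compound 2 `COc1cccc(CNc2nc(Nc3ccc(N4CCN(C)CC4)cn3)ncc2Cl)c1` gives 16200 nM as the higher of the two numbers. Compound 3 `Cc1ccc(Nc2nc(Nc3ccc(N4CCN(C)CC4)cn3)ncc2Cl)cc1` differs from compound 2 by 4-methylphenyl in place of 3-methoxybenzyl on a nitrogen on an aromatic ring. Among the measured compounds shown here, only one measured step bears on this: a 2.0-fold higher number from compound 1 to compound 2 (0.31 log units; beyond the scatter) (modest), with 3-methoxybenzyl in place of phenyl on that nitrogen. In this assay a step of similar size toward a lower number is therefore expected, namely a 2.0-fold lower number from compound 2 to compound 3 (0.31 log units; beyond the scatter) as an estimate. Compound 3 is estimated at 8000 nM with an expected range of 4000 nM to 16000 nM (a single step is thin support).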

Compound 3, concentration for 50% growth inhibition: 13900 nM
Compound 3: the middle estimate sits 1.7-fold (0.24 log units) below what was measured; the range from low to high includes it.
By their numbers in this assay, from the lowest: compounds 1, 3 and 2 (each within the scatter of the next, the first and the last beyond it).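

In this assay the nitrogen on an aromatic ring carries 4-methylphenyl or 3-methoxybenzyl with no separable difference, giving a 1.2-fold lower number from compound 2 to compound 3 (0.07 log units; within the scatter) as the step between them. Methyl in place of hydrogen on an aromatic carbon also stays inside the scatter, with a 1.7-fold higher number from compound 1 to compound 3 (0.24 log units; within the scatter) as its step. Among the compounds shown here, compound 1 and compound 2 thus remain the only pair of the three printed as beyond the scatter, and nothing available here explains these steps.

Open, from the compounds shown here alone, is whether a group without an aromatic ring on that nitrogen, such as a longer alkyl chain or a carboxylic acid, moves the number further. Also open, going by these compounds, is whether the methoxy group or the added methylene of 3-methoxybenzyl contributes on its own.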